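Notes on the step from compound 2 to compound 3

The source may report more compounds than this note shows. Statements on the series, on what has been measured and on what is new or still open speak of the compounds shown alone.

Measured so far:
compound 1 `CCCCCCc1cn(C(c2ccccc2)c2cc3cc(Br)ccc3nc2OC)nn1`: 6.08%
compound 2 `COc1nc2ccc(Br)cc2cc1C(c1ccccc1)n1cc(CO)nn1`: 15%

In an ADME assay on PANC-1 cells (Homo sapiens) for cytotoxicity, read by sulforhodamine B assay, with a stated time of 48 h, tested at 10 uM (a higher number here means more inhibition at the concentration tested (going by the name of the read-out), a lower number less inhibition), compound 1 gives 6.08% and compound 2 gives 15%. Compound 2 stands alongside compound 1, the step of a number 8.9 percentage points higher from compound 1 to compound 2 (within the scatter) being within the scatter. Compound 3 `CCOC(=O)c1cn(C(c2ccccc2)c2cc3cc(Br)ccc3nc2OC)nn1` differs from compound 2 by ethoxycarbonyl in place of hydroxymethyl on an aromatic carbon. For the measured compounds named here, no measured step bears on this change; the only step known, a number 8.9 percentage points higher from compound 1 to compound 2 (within the scatter), concerns a different change and was itself within the scatter. No step beyond the scatter is therefore expected. Compound 3 is estimated at 12%, with a range of 0% to 30%. The expected step is a number 3 percentage points lower from compound 2 to compound 3 (within the scatter).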

Compound 3, a percentage reported as inhibition, at one concentration (the size of the read-out at that concentration, not a potency): 15.4%
Beside the measured number, compound 3's estimate is 3.4 percentage points below it, within the range that was stated.
By their numbers in this assay, from the lowest: compounds 1, 2 and 3 (each within the scatter of the next).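

At this aromatic carbon of the five-membered aromatic ring, this assay separates ethoxycarbonyl neither from hydroxymethyl (a number 0.4 percentage points higher from compound 2 to compound 3 (within the scatter)) nor from hexyl (a number 9.3 percentage points higher from compound 1 to compound 3 (within the scatter)). The hydrogen-bond donor of hydroxymethyl is thus not required to keep the number within the scatter, since ethoxycarbonyl has 0 hydrogen-bond donors. No evidence bears on this result.

Across hexyl, hydroxymethyl and ethoxycarbonyl, no group at this position has yet given a step beyond the scatter. From the compounds shown here alone, whether an amine or a carboxylic acid there would do so remains open.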